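A few compounds are considered here, and "the series" means these few. Any claim that something is new, unique, unknown or untested is made for them only; others in the source may bear on it.

Measured compounds in a functional assay on DU-145 cells (Homo sapiens) for inhibition, read by MTT assay, with a stated time of 24 h; on this read-out lower numbers stand for stronger inhibition and higher numbers for weaker inhibition:
- compound 1 `CCOC(=O)C1=Cc2ccccc2OC1(OCc1cc(-c2ccc3ccccc3c2)no1)C(F)(F)F` gives 71800 nM.
- compound 2 `CCOC(=O)C1=Cc2ccccc2OC1(OCc1cc(-c2ccc(OC)cc2)no1)C(F)(F)F` gives > 150000 nM, which is a limit of this assay.
- compound 3 `CCOC(=O)C1=Cc2ccccc2OC1(OCc1cc(-c2ccc(Cl)cc2)no1)C(F)(F)F` gives 18200 nM.

Among the two numbers, compound 1 stands highest; compound 3 is nearest, with a 3.9-fold lower number from compound 1 to compound 3 (0.60 log units; beyond the scatter). The value for compound 2 is a limit rather than a number (the limit of > 150000 nM in this assay, at which 1 of the 3 values shown sits).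

All three measured steps alter the group on an aromatic carbon: an at least 2.0-fold higher number from compound 1 to compound 2 (0.31 log units; beyond the scatter), a 3.9-fold lower number from compound 1 to compound 3 (0.60 log units; beyond the scatter) and an at least 8.2-fold lower number from compound 2 to compound 3 (0.91 log units; beyond the scatter). They say nothing about the ester.

Compound 4 `O=C(O)C1=Cc2ccccc2OC1(OCc1cc(-c2ccc3ccccc3c2)no1)C(F)(F)F` differs from compound 1 by hydrogen in place of ethyl on an oxygen next to a carbonyl group. Among the measured compounds shown here, no measured step bears on this change; the ester is kept unchanged in compounds 1, 2 and 3. Direction and size of the step in this assay are therefore not anchored by anything measured, and the expectation is a step that is not beyond the scatter, with a wide range and a fair chance that only a limit is reported. Compound 4 is expected at 80000 nM (range 25000 nM to 200000 nM). This estimate means a 1.1-fold higher number from compound 1 to compound 4 (0.05 log units; within the scatter).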

Compound 4, half-maximal inhibitory concentration: 141000 nM
Estimate against measurement, compound 4: 1.8-fold (0.25 log units) below; the range from low to high includes it.
By their numbers in this assay, from the lowest: compound 3; then compounds 1 and 4 (each within the scatter of the next). At a limit, above all of these: compound 2.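

In this assay the ester position now has a first reading, with a 2.0-fold higher number from compound 1 to compound 4 (0.29 log units; within the scatter) for ethoxycarbonyl to carboxy on the naphthalen-2-yl compound, and this step cannot be told apart from the scatter. The earlier steps all concern the aromatic group and each lies beyond the scatter, as in a 3.9-fold lower number from compound 1 to compound 3 (0.60 log units; beyond the scatter) for example, so among these compounds only changes of that aromatic group stand clear of it. The value of compound 2 remains a limit and not a number: the limit of > 150000 nM in this assay, at which 1 of the 4 values shown sits.

As far as these compounds go, the ester step rests on a single pair carrying naphthalen-2-yl, so whether hydrogen in place of ethyl gives a similar result with 4-chlorophenyl or 4-methoxyphenyl stays open. Also open, from the compounds shown here alone, is how other groups at this position would read, such as a primary amide, a methyl ester or a longer chain like butyl on the oxygen next to the carbonyl group.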